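Compound 3: pyridin-4-yl in place of pyridin-3-yl

A few compounds are considered here, and "the series" means these few. Any claim that something is new, unique, unknown or untested is made for them only; others in the source may bear on it.

In a physicochemical assay for solubility, read by HPLC, with a stated time of 24 h, at pH 7.4, tested at 250 uM (on this read-out lower numbers stand for lower solubility and higher numbers for higher solubility), compound 1 `CN1CCN(CCCNc2nc(-c3cccnc3)nc3c2CN(Cc2ccccc2)CC3)CC1` gives 234000 nM and compound 2 `CN(C)CCN1CCN(c2nc(-c3cccnc3)nc3c2CN(Cc2ccccc2)CC3)CC1` gives 247000 nM. Compound 2 therefore stands level with compound 1, the two numbers lying within the scatter of each other. Compound 3 `CN(C)CCN1CCN(c2nc(-c3ccncc3)nc3c2CN(Cc2ccccc2)CC3)CC1` carries pyridin-4-yl in place of pyridin-3-yl on an aromatic carbon, between two ring nitrogen atoms and meta to a 4-(2-(dimethylamino)ethyl)piperazin-1-yl group: pyridin-4-yl in place of pyridin-3-yl on an aromatic carbon. Going by the values given here, no measured step touches the pyridinyl group. Among the compounds with values here, the only step available, a 1.1-fold higher number from compound 1 to compound 2 (0.02 log units; within the scatter), exchanges a different substituent and bears on this change only indirectly. Within the data shown here, with that step as the sole guide, no step beyond the scatter is expected in this assay, and no direction can be argued. The expected step is a 1.1-fold lower number from compound 2 to compound 3 (0.03 log units; within the scatter). Compound 3 is estimated at 230000 nM, with an expected range of 150000 nM to 260000 nM.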

Compound 3, solubility: 250000 nM
Estimate against measurement, compound 3: 1.1-fold (0.04 log units) below; the range from low to high includes it.
By their numbers in this assay, from the lowest: compounds 1, 2 and 3 (each within the scatter of the next).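

In this assay, going by these compounds alone, the first measured step at this position, pyridin-4-yl in place of pyridin-3-yl on the aromatic carbon between two ring nitrogen atoms, reads a 1.0-fold higher number from compound 2 to compound 3 (0.01 log units; within the scatter) and lies within the scatter. With the same atoms joined differently and the 4-(2-(dimethylamino)ethyl)piperazin-1-yl group held constant, this exchange of pyridinyl isomers leaves the read-out level for this pair. No available evidence bears on why the pair stands level.

From the compounds shown here alone, whether pyridin-2-yl or phenyl at this position would also stay within the scatter remains open. Going by these compounds, the benzyl group on the shared core is common to all three compounds, so the outcome of replacing it with a carboxylic acid or a longer chain is also open.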